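Compound 4: 2-fluorophenyl in place of 4-hydroxyphenyl

The compounds below may be only part of what the source reports. "The series", "measured", "known", "first", "only" and "open" are said of these compounds alone.

Compound 1 `Cn1c(=O)c(=O)n(C2CCCC2)c2nc(N/N=C/c3ccc(O)cc3)ncc21` is the anchor of this set. In a functional assay on A549 cells (Homo sapiens) for antiproliferative activity, read by MTT assay (on this read-out higher numbers stand for weaker inhibition and lower numbers for stronger inhibition), compound 1 gives only a limit, > 100000 nM, so its true position is open (the limit of > 100000 nM in this assay, at which 1 of the 3 values shown sits). Compound 2 `Cn1c(=O)c(=O)n(C2CCCC2)c2nc(N/N=C/c3ccc(O)c(F)c3)ncc21` gives 97800 nM in this assay, and compound 3 `Cn1c(=O)c(=O)n(C2CCCC2)c2nc(N/N=C/c3ccc(F)cc3Cl)ncc21` gives 11000 nM. Among the compounds with values here, two measured steps bear on the change at hand. The step of an at least 1.0-fold lower number from compound 1 to compound 2 (0.00 log units; that floor lies within the scatter) shows that a fluoro for hydrogen on the aromatic ring alone moves nothing that can be trusted. The step of an at least 9.0-fold lower number from compound 1 to compound 3 (0.95 log units; beyond the scatter), with an 8.9-fold lower number from compound 2 to compound 3 (0.95 log units; beyond the scatter) pointing the same way, shows that swapping the hydroxyphenyl for a halogenated phenyl brings a real gain.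

Compound 4 `Cn1c(=O)c(=O)n(C2CCCC2)c2nc(N/N=C/c3ccccc3F)ncc21` has not been measured. It differs from compound 1 by 2-fluorophenyl in place of 4-hydroxyphenyl on a carbon with a double bond to nitrogen. The 4-hydroxyphenyl leaves as in the step to compound 3, but only a single fluorine enters instead of a chlorine and a fluorine, so a gain is expected, likely smaller than that of compound 3 and possibly not beyond the scatter. Compound 4 is therefore expected to give about 35000 nM in this assay, with a range from 10000 nM to 120000 nM, which as a step would be estimated at an at least 2.8-fold lower number from compound 1 to compound 4 (0.45 log units; beyond the scatter).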

Compound 4, half-maximal inhibitory concentration: 31200 nM
The estimate for compound 4 lay 1.1-fold (0.05 log units) above the measured number, and the stated range covers the measured number.
By their numbers in this assay, from the lowest: compound 3; then compound 4; then compound 2. At a limit, above all of these: compound 1.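

In this assay, 2-fluorophenyl on the carbon with a double bond to nitrogen gives a change beyond the scatter without any chlorine on the ring, with an at least 3.2-fold lower number from compound 1 to compound 4 (0.50 log units; beyond the scatter) and a 3.1-fold lower number from compound 2 to compound 4 (0.50 log units; beyond the scatter). Compound 3 still keeps an edge, seen as a 2.8-fold higher number from compound 3 to compound 4 (0.45 log units; beyond the scatter), so the gain at this place depends on which halogens the phenyl carries and not only on the 4-hydroxyphenyl leaving. The gain over compound 1 remains a floor, as the value of compound 1 is only a limit: the limit of > 100000 nM in this assay, at which 1 of the 4 values shown sits.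

An unsubstituted phenyl would show how much of the gain comes from losing the hydroxyl and how much from the entering fluorine. Going by these compounds, how an amine or a carboxylic acid on this phenyl would read in this assay remains open.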